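Ring-nitrogen substituent: benzyl against alkyl in the anilide series

The source may report more compounds than this note shows. Statements on the series, on what has been measured and on what is new or still open speak of the compounds shown alone.

Compound 3 `CCCCCN1CCC(C(=O)Nc2cc(Cl)c(N)cc2OC)CC1` carries a pentyl chain on the ring nitrogen. In a functional assay on the whole organism for antagonist activity, with Mus musculus as the target (a lower number here means that less compound is needed, a higher number that more compound is needed for the effect), compound 3 gives only a limit, > 10 mg/kg. Compound 1 `CCCCCCCN1CCC(C(=O)Nc2cc(Cl)c(N)cc2OC)CC1`, the heptyl analogue, also gives only a limit, > 10 mg/kg. Within the data shown here, compound 2 `CCOc1ccc(CN2CCC(C(=O)Nc3cc(Cl)c(N)cc3OC)CC2)cc1`, with a 4-ethoxybenzyl group, is the one member with a number, 6.3 mg/kg in this assay. Two of the three values sit at the limit (the limit of > 10 mg/kg in this assay, at which 2 of the 3 values shown sit). The step that the two limits leave unreadable from compound 1 to compound 3 is unreadable, whereas an at least 1.5-fold lower number from compound 1 to compound 2 (0.20 log units; that floor lies within the scatter) and an at least 1.5-fold higher number from compound 2 to compound 3 (0.20 log units; that floor lies within the scatter) both point the same way. Compound 4 `COc1cc(N)c(Cl)cc1NC(=O)C1CCN(Cc2ccccc2F)CC1` makes a related change: 2-fluorophenyl in place of butyl on a saturated chain carbon bound to an amine nitrogen in a ring. Since a substituted phenyl in place of an alkyl chain went with a lower number in an at least 1.5-fold lower number from compound 1 to compound 2 (0.20 log units; that floor lies within the scatter), a step of an at least 2.0-fold lower number from compound 3 to compound 4 (0.30 log units; that floor lies within the scatter) is expected, and compound 4 is estimated at 5 mg/kg, within 2 mg/kg to 15 mg/kg.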

Compound 4, dose for half-maximal effect: > 4 mg/kg
Compound 4 ended at the assay's limit (the forecaster's own chance of this, stated with the estimate: 35%); the middle value lies beyond the limit too.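

Compound 4 gives only a limit, > 4 mg/kg, so its steps from compound 1, compound 2 and compound 3 cannot be read. Left open is whether the 2-fluorobenzyl group of compound 4 matches the 4-ethoxybenzyl group of compound 2 in this assay.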